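The source may hold more compounds than are shown below. What is called first, only, known or untested is meant among the compounds shown, and "the series" means these compounds.

Compound 1, `COc1ccc(-c2cc(-c3ccc4c(c3)CCCC4)nc3[nH]nc(N)c23)cc1OC`, and compound 2, `CC(C)c1ccc(-c2cc(-c3ccc4c(c3)CCCC4)nc3[nH]nc(N)c23)cc1`, share one core, and both are reported only as limits in an ADME assay on RAW264.7 cells (Mus musculus) for cytotoxicity, with a stated time of 24 h; on this read-out lower numbers stand for stronger inhibition and higher numbers for weaker inhibition. Compound 1 gives > 50000 nM, which is a limit of the assay rather than a number. Compound 2 gives > 50000 nM, likewise a limit. Between them lies a step that the two limits leave unreadable from compound 1 to compound 2, and it cannot be read because the limit of > 50000 nM in this assay, at which 2 of the 3 values shown sit, hides both ends of it. Compound 3, `COc1ccc(-c2cc(-c3ccc4c(c3)CCCC4)nc(OCC(=O)NN)c2C#N)cc1OC`, has a different core; how the two cores differ is not broken down here. In this assay, among the measured compounds shown here, compound 3 gives 3100 nM, the only number among the three.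

Compound 4, `CC(C)c1ccc(-c2cc(-c3ccc4c(c3)CCCC4)nc(OCC(=O)NN)c2C#N)cc1`, repeats the same kind of change on the core of compound 3: 4-isopropylphenyl in place of 3,4-dimethoxyphenyl on an aromatic carbon. In compound 2 the change stands as 4-isopropylphenyl in place of 3,4-dimethoxyphenyl on an aromatic carbon, so the surroundings of the place differ and the two changes are of the same kind, not the same. Since the earlier step is unreadable, the step expected from compound 3 to compound 4 is a 1.1-fold higher number from compound 3 to compound 4 (0.05 log units; within the scatter), a modest one. Compound 4 is therefore estimated at 3500 nM, expected between 1200 nM and 12000 nM.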

Compound 4, half-maximal inhibitory concentration: 27700 nM
Beside the measured number, compound 4's estimate is 7.9-fold (0.90 log units) below it, and the stated range ends below it.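

In this assay, putting 4-isopropylphenyl in place of 3,4-dimethoxyphenyl on the core that carries the (aminocarbamoyl)methoxy group gives an 8.9-fold higher number from compound 3 to compound 4 (0.95 log units; beyond the scatter), so on this core the change moves the read-out towards weaker inhibition by more than the usual scatter. The same change on the other core cannot be read, since compound 1 and compound 2 both stand at a limit of the assay and not at a number: the limit of > 50000 nM in this assay, at which 2 of the 4 values shown sit. The series therefore gives a size for this change on one core only, and it shows neither that the size carries over to the other core nor that it fails to.

The compounds shown leave open which part of the change matters, the departure of the two methoxy groups or the arrival of the isopropyl group, and a phenyl ring bearing a single methoxy group would separate the two. Also open, on these data alone, is how this assay would respond to an amine or a carboxylic acid in place of the (aminocarbamoyl)methoxy group.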